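Stretching One Arm of Compound 2 by a Double Bond

The source may hold more compounds than are shown below. What is called first, only, known or untested is meant among the compounds shown, and "the series" means these compounds.

All four compounds share one core. In a functional assay on HL-60 cells (Homo sapiens) for cytotoxicity, read by MTT assay, with a stated time of 48 h (a lower number here means a stronger inhibitor, a higher number a weaker inhibitor), compound 1 `CC(=O)O[C@H]1C=CC(=O)O[C@@H]1/C=C/c1ccccc1` gives 2680 nM and compound 2 `CC(=O)O[C@H]1C=CC(=O)O[C@@H]1c1nc(-c2ccccc2)oc1-c1ccccc1` gives 2590 nM; these two numbers lie within the scatter of each other, so neither can be called the stronger. Compound 3 `CC(=O)O[C@H]1C=CC(=O)O[C@@H]1[C@@H](O)[C@H](O)c1ccccc1` reaches only the limit > 40000 nM in this assay, which is the limit of > 40000 nM in this assay, at which 1 of the 3 values shown sits. Compound 4 `CC(=O)O[C@H]1C=CC(=O)O[C@@H]1c1nc(/C=C/c2ccccc2)oc1-c1ccccc1` differs from compound 2 in one place (2-phenylethenyl in place of phenyl on an aromatic carbon). Among the compounds with values here, no measured pair shows this kind of change, so the expectation in this assay rests on compound 1 alone, whose 2-phenylethenyl attached directly to the core gives 2680 nM, close to compound 2. The expected step is a 1.4-fold lower number from compound 2 to compound 4 (0.16 log units; within the scatter), small and probably within the scatter. Compound 4 is thus expected to give 1800 nM, between 600 nM and 6000 nM.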

Compound 4, half-maximal inhibitory concentration: 5890 nM
Compound 4: the middle estimate sits 3.3-fold (0.51 log units) below what was measured, within the range that was stated.
By their numbers in this assay, from the lowest: compounds 2 and 1 (each within the scatter of the next); then compound 4. At a limit, above all of these: compound 3.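

In this assay, 2-phenylethenyl proves no equal swap for phenyl on this aromatic carbon, next to the ring nitrogen and next to the ring oxygen: the change gives a 2.3-fold higher number from compound 2 to compound 4 (0.36 log units; beyond the scatter). Within the data shown here, this is the only measured change at this position, and it shows that the position responds to a longer arm, though modestly. The data shown offer no explanation for this step.

Going by these compounds, what a 2-phenylethyl group or an amine on this carbon would give remains open, as does whether the double bond or the added length accounts for the step.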